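Piperidin-1-yl in Place of Dimethylamino on a Shared Core

A few compounds are considered here, and "the series" means these few. Any claim that something is new, unique, unknown or untested is made for them only; others in the source may bear on it.

In an assay on isolated protein for inhibition of DNA topoisomerase 1 (Homo sapiens), with a stated time of 30 min, tested at 20 uM (on this read-out higher numbers stand for a stronger effect at the one concentration tested and lower numbers for a weaker effect), the measured compounds gave the following:
Compound 1, `CN(C)c1ccc2nc(-c3cccc4ccccc34)[nH]c(=O)c2c1`: 2.4%
Compound 2, `Cc1cccc(-c2nc3ccc(C)cc3c(=O)[nH]2)c1`: 12.7%
Compound 3, `Cc1ccc2nc(-c3ccccc3C)[nH]c(=O)c2c1`: "not determined" (no result reported)

Compound 1 stands lowest of the two numbers in this assay. Its nearest neighbour is compound 2, whose value lies higher by a margin beyond the usual scatter, so the two compounds are distinguishable on this read-out. Compound 3 contributes no number and cannot be placed. Going by the values given here, no two measured compounds differ in a single place, so no measured step is available as a guide.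

Compound 4, `O=c1[nH]c(-c2cccc3ccccc23)nc2ccc(N3CCCCC3)cc12`, is not yet measured. It differs from compound 1 in one place: piperidin-1-yl in place of dimethylamino on an aromatic carbon. The piperidin-1-yl group enters where the dimethylamino group leaves, on an aromatic carbon of the six-membered carbon ring within the fused system.

With nothing in the measured set that bears directly on this change, the expectation rests on compound 1 alone. The step of a number 3.6 percentage points higher from compound 1 to compound 4 (within the scatter) is expected to be small, with no direction that clearly exceeds the scatter. Compound 4 is therefore estimated at 6%, with a range from -5% to 20%.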

Compound 4, a percentage reported as inhibition, at one concentration (the size of the read-out at that concentration, not a potency): 33.4%
Compound 4: the middle estimate sits 27.4 percentage points below what was measured; measured number above the stated range.
By their numbers in this assay, from the lowest: compound 1; then compound 2; then compound 4.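

In this assay, going by these compounds alone, piperidin-1-yl in place of dimethylamino on the aromatic carbon gives a number 31 percentage points higher from compound 1 to compound 4 (beyond the scatter) and is the first single-place change that can be read in this set. It shows that the read-out at this position, meta to a fused ring and para to a fused ring, responds to the group attached there, even though both groups have a single nitrogen, the same counts of hydrogen-bond donors and acceptors, and no net charge. What differs in the computed comparison is the number of heavy atoms, 6 against 3, and the six-membered non-aromatic ring, but no measurement here bears on why the value changes.

Within the data shown here, the single step cannot separate the contribution of the ring from that of the added carbon atoms, a question that diethylamino, an open-chain group, or pyrrolidin-1-yl, a smaller ring, could address. It also leaves open whether a second hetero atom in the ring, as in morpholin-4-yl, would keep the step, and whether the same exchange would give a similar step with a different group in place of the one at the other end of the shared core.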